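This account rests on a few compounds, and the source may have more. Where it says the series, first, only, none or still open, it means among the compounds named here.

Measured so far in a physicochemical assay for solubility, in phosphate buffer, measured as thermodynamic solubility, at pH 7.4 (a higher number here means a more soluble compound, a lower number a less soluble compound), for three compounds:
- compound 1 `CS(=O)(=O)NC(=O)CCc1cn(-c2ccc(Br)cc2)nc1-c1ccc(Cl)cc1` gives 170000 nM
- compound 2 `CS(=O)(=O)NC(=O)CCc1cn(-c2ccc(Br)cc2)nc1-c1cccnc1` gives 200000 nM
- compound 3 `CS(=O)(=O)NC(=O)CCc1cn(-c2ccc(Br)cc2)nc1C1CCOCC1` gives 200000 nM

Compound 3 stands level with compound 2 at the digits shown and within the scatter of compound 1. Compound 4 `CS(=O)(=O)NC(=O)CCc1cn(-c2ccc(Br)cc2)nc1-c1ccc(N)cc1` differs from compound 3 as follows 4-aminophenyl in place of oxan-4-yl on an aromatic carbon and so carries 4-aminophenyl in place of oxan-4-yl on an aromatic carbon.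

All three measured steps changed the group at this same place. Closest to the new change is the exchange of 4-chlorophenyl for oxan-4-yl, which gave a 1.2-fold higher number from compound 1 to compound 3 (0.07 log units; within the scatter) in this assay as its result. The other two steps, a 1.2-fold higher number from compound 1 to compound 2 (0.07 log units; within the scatter) and no change at the digits printed from compound 2 to compound 3 (within the scatter) are equally small. Among the compounds with values here, no measured compound carries 4-aminophenyl, so that group remains untested.

The expected step is a 1.1-fold lower number from compound 3 to compound 4 (0.05 log units; within the scatter) and so none beyond the scatter. For compound 4 the estimated value is 180000 nM with an expected range from 100000 nM to 300000 nM in this read-out.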

Compound 4, solubility: 160000 nM
Beside the measured number, compound 4's estimate is 1.1-fold (0.05 log units) above it, and the stated range covers the measured number.
By their numbers in this assay, from the lowest: compounds 4, 1, 2 and 3 (each within the scatter of the next).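

In this assay, the aromatic carbon next to the ring nitrogen also accepts 4-aminophenyl, which carries a hydrogen-bond donor that oxan-4-yl lacks, and the steps stay within the scatter (from oxan-4-yl: a 1.3-fold lower number from compound 3 to compound 4 (0.10 log units; within the scatter); from pyridin-3-yl: a 1.3-fold lower number from compound 2 to compound 4 (0.10 log units; within the scatter)). Amino in place of chloro on the aromatic carbon is also within the scatter (a 1.1-fold lower number from compound 1 to compound 4 (0.03 log units; within the scatter)), so all four compounds, with aromatic and non-aromatic groups at this place, cannot be told apart in this read-out. Nothing available here accounts for this.

The compounds shown leave open whether a carboxylic acid or a longer chain ending in an amine at this place would move the number beyond the scatter. They also leave open what replacing the 4-bromophenyl group or the 2-((methylsulfonyl)carbamoyl)ethyl group would do.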